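The source may hold more compounds than are shown below. What is called first, only, known or untested is meant among the compounds shown, and "the series" means these compounds.

Compound 1 `Nc1ncnc2c1c(-c1cnc3[nH]ccc3c1)nn2CCCCCCCCC(=O)NO`: in a functional assay on CNE-2 cells (Homo sapiens) for inhibition, read by MTT assay, with a stated time of 72 h (on this read-out lower numbers stand for stronger inhibition and higher numbers for weaker inhibition), compound 1 gives 2270 nM.
Compound 2 `Nc1nc2cc(-c3nn(CCCC(=O)NO)c4ncnc(N)c34)ccc2o1`: compound 2 gives > 50000 nM, which is a limit of the assay and not a number.
Compound 3 `CNC(=O)CCCCCCCn1nc(-c2ccc3oc(N)nc3c2)c2c(N)ncnc21`: compound 3 gives 2250 nM.

Compound 2 thus stands at the limit of > 50000 nM in this assay, at which 1 of the 3 values shown sits, with no number of its own. Compound 4 `Nc1nc2cc(-c3nn(CCCCCCC(=O)NO)c4ncnc(N)c34)ccc2o1` differs from compound 2 by 3-(hydroxycarbamoyl)propyl in place of hydroxycarbamoyl on a saturated chain carbon, three bonds along the chain from an aromatic nitrogen. Within the data shown here, one measured step bears on this change: an at least 22-fold lower number from compound 2 to compound 3 (1.34 log units; beyond the scatter), a lengthening of the chain that ended in a methylcarbamoyl group. Compound 1, which carries its hydroxycarbamoyl group on a longer chain, gives 2270 nM. A lengthened hydroxycarbamoyl chain is therefore expected to produce an at least 16-fold lower number from compound 2 to compound 4 (1.22 log units; beyond the scatter). Compound 4 is estimated at 3000 nM, between 1000 nM and 12000 nM.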

Compound 4, half-maximal inhibitory concentration: 4360 nM
For compound 4 the middle estimate is 1.5-fold (0.16 log units) below the measured one; measured number inside the range.
By their numbers in this assay, from the lowest: compounds 3, 1 and 4 (each within the scatter of the next). At a limit, above all of these: compound 2.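

In this assay, 3-(hydroxycarbamoyl)propyl in place of hydroxycarbamoyl now gives a direct reading with the hydroxycarbamoyl end kept: an at least 11-fold lower number from compound 2 to compound 4 (1.05 log units; beyond the scatter). Compound 2 stands at a limit of the assay and not at a number: the limit of > 50000 nM in this assay, at which 1 of the 4 values shown sits. The chain end itself makes no difference that can be read here, with a 1.9-fold higher number from compound 3 to compound 4 (0.29 log units; within the scatter), so a lower number on lengthening does not depend on a methylcarbamoyl end.

On these data alone, what remains open is how a chain of intermediate length would read on this core. As far as these compounds go, whether a carboxylic acid or an amine at the chain end would give a similar number also remains open.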